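Trifluoromethyl on the Phenyl Arm of Compound 2

The source may report more compounds than this note shows. Statements on the series, on what has been measured and on what is new or still open speak of the compounds shown alone.

Compound 1 `Cc1ccc(-c2cc3nccc(-c4ccc(F)cc4)n3n2)cc1`: in a functional assay on A549 cells (Homo sapiens) for inhibition, read by CCK-8 assay, with a stated time of 48 h (a lower number here means a stronger inhibitor, a higher number a weaker inhibitor), compound 1 gives > 10000 nM, which is a limit of the assay rather than a number.
Compound 2 `COc1cc(-c2ccnc3cc(-c4ccccc4)nn23)cc(OC)c1OC`: in this assay compound 2 gives 208 nM.
Compound 3 `COc1cc(-c2ccnc3cc(-c4cn(C(=O)OC(C)(C)C)c5ccccc45)nn23)cc(OC)c1OC`: in this assay compound 3 gives 2070 nM.

Of the two compounds with a number, compound 2 has the lower one, and its gap to compound 3 lies beyond the usual scatter. Compound 4 `COc1cc(-c2ccnc3cc(-c4ccc(C(F)(F)F)cc4)nn23)cc(OC)c1OC` has not yet been measured. It differs from compound 2 in one place: trifluoromethyl in place of hydrogen on an aromatic carbon. For the measured compounds named here, no measured pair shows this same change, so there is no direct guide to its size. The expected step from compound 2 to compound 4 is small, at most a modest weakening, written as a 1.5-fold higher number from compound 2 to compound 4 (0.19 log units; within the scatter). Compound 4 is therefore estimated at 320 nM, with a likely range from 110 nM to 1200 nM.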

Compound 4, half-maximal inhibitory concentration: 2070 nM
Beside the measured number, compound 4's estimate is 6.5-fold (0.81 log units) below it; the whole stated range lies below it.
By their numbers in this assay, from the lowest: compound 2; then compounds 3 and 4 (each within the scatter of the next). At a limit, above all of these: compound 1.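

Phenyl to 4-(trifluoromethyl)phenyl is the first single change whose size can be read in this assay, and it brings a 10-fold higher number from compound 2 to compound 4 (1.00 log units; beyond the scatter) on this arm. This position is therefore not indifferent to substitution, since one added group weakens inhibition beyond the scatter. The data shown give no reason for the size of this step. Open, from the compounds shown here alone, is how other groups on this same aromatic carbon would behave, such as an amine or a carboxylic acid. Also open, going by these compounds, is whether this step would keep its size on another arm.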